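From Pyridin-3-yl to 3-Aminophenyl on the Carbonyl Carbon

This account rests on a few compounds, and the source may have more. Where it says the series, first, only, none or still open, it means among the compounds named here.

Measured compounds:
compound 1, `O=C(/C=C/c1ccc2c(c1)B(O)OC2)c1cccnc1`: 18500 nM
compound 2, `Cc1ccc(C(=O)/C=C/c2ccc3c(c2)B(O)OC3)cc1C`: 1900 nM
compound 3, `O=C(/C=C/c1ccc2c(c1)B(O)OC2)c1ccccc1O`: 48800 nM

Of the compounds shown here, three sharing one core have been tested in a functional assay on SK-OV-3 cells (Homo sapiens) for cytotoxicity, read by MTT assay, with a stated time of 48 h; a higher number here means a weaker inhibitor, a lower number a stronger inhibitor. Compound 1 stands second highest of the three numbers; its nearest neighbour is compound 3, a step of a 2.6-fold higher number from compound 1 to compound 3 (0.42 log units; beyond the scatter), and its furthest is compound 2, whose value sits well below that of compound 1, beyond the scatter.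

The compound now in question is compound 4, `Nc1cccc(C(=O)/C=C/c2ccc3c(c2)B(O)OC3)c1`. It differs from compound 1 in one place: 3-aminophenyl in place of pyridin-3-yl on a carbonyl carbon.

Going by the values given here, only one measured step touches the same place, the replacement of pyridin-3-yl by 2-hydroxyphenyl, a 2.6-fold higher number from compound 1 to compound 3 (0.42 log units; beyond the scatter), which raised the number modestly. Among the compounds with values here, compound 2 shows that a carbon-only ring with methyl groups at this position gives a much lower number than compound 1, but no step from compound 1 to compound 2 is available as a single change, so it is only a hint. Within the data shown here, the two phenyl-bearing compounds point in opposite directions, and the aminophenyl group itself has no measured precedent here. The expected step from compound 1 to compound 4 is therefore small, a 1.7-fold lower number from compound 1 to compound 4 (0.23 log units; within the scatter), and might lie within the scatter. Compound 4 is estimated at 11000 nM, with a range from 3500 nM to 35000 nM.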

Compound 4, half-maximal inhibitory concentration: 7400 nM
Compound 4: the middle estimate sits 1.5-fold (0.17 log units) above what was measured; measured number inside the range.
By their numbers in this assay, from the lowest: compound 2; then compound 4; then compound 1; then compound 3.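

In this assay, the place on the carbonyl carbon now has two measured steps out of compound 1, and they run in opposite directions: 2-hydroxyphenyl gives a 2.6-fold higher number from compound 1 to compound 3 (0.42 log units; beyond the scatter), while 3-aminophenyl gives a 2.5-fold lower number from compound 1 to compound 4 (0.40 log units; beyond the scatter), each beyond the scatter. Replacing pyridin-3-yl with a phenyl-based group therefore does not by itself set the direction of the change, since the two phenyl-based groups are themselves separated by a 6.6-fold lower number from compound 3 to compound 4 (0.82 log units; beyond the scatter), and the outcome here depends on which group the phenyl ring carries. The information at hand offers no explanation for why these groups differ as they do.

The compounds shown leave open how an unsubstituted phenyl group would compare at this place, and so whether the amine of compound 4 or the ring itself accounts for its lower number relative to compound 1. They also leave open how a carboxylic acid or a methoxy group in place of that amine would read, and whether the steps seen here would hold on a core other than the shared one.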